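Replacing the amino group of compound 1 with bromo

The compounds below may be only part of what the source reports. "The series", "measured", "known", "first", "only" and "open" are said of these compounds alone.

compound 1 `Nc1nc2cc(Cl)c(Cl)cc2n1Cc1ccc(Cl)cc1`: 45000 nM
compound 2 `CC(C)(C)c1ccc(Cn2c(N)nc3cc(Cl)c(Cl)cc32)cc1`: 50000 nM
compound 3 `Nc1nc2cc(Cl)c(Cl)cc2n1Cc1ccc([N+](=O)[O-])cc1`: 35000 nM

In a functional assay on KB cells (Homo sapiens) for inhibition (a lower number here means a stronger inhibitor, a higher number a weaker inhibitor), compound 1 gives 45000 nM and stands within the scatter of both other compounds: a 1.1-fold higher number from compound 1 to compound 2 (0.05 log units; within the scatter) and a 1.3-fold lower number from compound 1 to compound 3 (0.11 log units; within the scatter). The remaining pair agrees with this, showing a 1.4-fold lower number from compound 2 to compound 3 (0.15 log units; within the scatter). The three measured compounds therefore form one flat group, and their values do not separate them.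

The unmeasured compound 4 `Clc1ccc(Cn2c(Br)nc3cc(Cl)c(Cl)cc32)cc1` differs from compound 1 at another place: bromo in place of amino on an aromatic carbon. The measured steps exchange chloro, tert-butyl and nitro at a single site, and all three compounds keep the amino group. Within the data shown here, none of these steps tests the new change directly, and no measured compound lacks the amino group, so the data give no direction for it. The best available anchor is compound 1 at 45000 nM, and no step beyond the scatter is expected, although real uncertainty remains in both directions. The estimated step is a 1.1-fold lower number from compound 1 to compound 4 (0.05 log units; within the scatter). For compound 4 the expected value is 40000 nM, with an estimated range from 10000 nM to 100000 nM.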

Compound 4, half-maximal inhibitory concentration: > 100000 nM
Compound 4 ended at the assay's limit; the forecaster's own chance of this, stated with the estimate: 20%; at least 2.5-fold (0.39 log units) between middle value and limit.
By their numbers in this assay, from the lowest: compounds 3, 1 and 2 (each within the scatter of the next). At a limit, above all of these: compound 4.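

In this assay the swap of amino for bromo, on the aromatic carbon between two ring nitrogen atoms, gives an at least 2.2-fold higher number from compound 1 to compound 4 (0.34 log units; beyond the scatter) and so weakens inhibition, whereas exchanging chloro, tert-butyl and nitro at the other site left the compounds within the scatter of one another. Among these compounds, this is the first sign that the number responds to a change at this carbon, and it responds in the weaker direction. Compound 4 sits at a limit of the assay, so the step gives only a lower bound on the size of the change: the limit of > 100000 nM in this assay, at which 1 of the 4 values shown sits.

Amino brings a hydrogen-bond donor and acceptor by the count and bromo brings neither, but a single replacement cannot show whether that difference matters, or whether any other group at this carbon, such as a hydroxyl, a methyl or a methylamino group, would keep the number of compound 1. From the compounds shown here alone, it also remains open whether bromo would give a similar step in compounds carrying tert-butyl or nitro in place of the chloro.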